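This account rests on a few compounds, and the source may have more. Where it says the series, first, only, none or still open, it means among the compounds named here.

Measured compounds:
Compound 1, `CC1=C(/C=C/C(=O)/C=C/c2ccc(Cl)cc2)C(C)(C)CCC1`: 90600 nM in a functional assay on Hep cells (Homo sapiens) for cytotoxicity, read by sulforhodamine B assay, with a stated time of 48 h; on this read-out higher numbers stand for weaker inhibition and lower numbers for stronger inhibition
Compound 2, `CC1=C(/C=C/C(=O)/C=C/c2ccc(F)cc2)C(C)(C)CCC1`: 55800 nM in this assay
Compound 3, `COc1ccc(/C=C/C(=O)/C=C/C2=C(C)CCCC2(C)C)cc1`: > 100000 nM in this assay, a limit of the assay and not a number.

Compound 3 thus stands only at a limit in this assay, at the limit of > 100000 nM in this assay, at which 1 of the 3 values shown sits, so its true value is not resolved. The steps that reach it, an at least 1.1-fold higher number from compound 1 to compound 3 (0.04 log units; that floor lies within the scatter) and an at least 1.7-fold higher number from compound 2 to compound 3 (0.25 log units; that floor lies within the scatter), both lie within the scatter, as does a 1.6-fold lower number from compound 1 to compound 2 (0.21 log units; within the scatter) among the halogen analogues; none of the three shifts is meaningful. Compound 4, `COc1ccc(/C=C/C(=O)/C=C/C2=C(C)CCCC2(C)C)cc1OC`, differs from compound 3 by methoxy in place of hydrogen on an aromatic carbon. No measured step among these compounds adds a second methoxy, so the only guide is that every change on this aromatic ring so far has stayed within the scatter and that compound 3 already sits at the limit. Compound 4 is therefore expected to give 140000 nM, within a range from 55000 nM to 400000 nM, and quite possibly again only a limit. For compound 4 this means an estimated step that the limit leaves unreadable from compound 3 to compound 4, that is, no step beyond the scatter.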

Compound 4, half-maximal inhibitory concentration: 72400 nM
The estimate for compound 4 lay 1.9-fold (0.29 log units) above the measured number; the range from low to high includes it.
By their numbers in this assay, from the lowest: compounds 2, 4 and 1 (each within the scatter of the next). At a limit, above all of these: compound 3.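

Compound 3 stands only at a limit of this assay, not at a number: the limit of > 100000 nM in this assay, at which 1 of the 4 values shown sits.

A methoxy in place of hydrogen, ortho to a methoxy group and meta to a large group, gives in compound 4 a value that can be read as a number, and that value lies among those of the halogen analogues, compound 1 and compound 2, within the scatter. The step itself, an at least 1.3-fold lower number from compound 3 to compound 4 (0.14 log units; that floor lies within the scatter), is only a floor, so it does not show that this second methoxy strengthens inhibition, only that the position carries the group without the read-out going to the limit.

Going by these compounds, the true distance between these two compounds remains open. Also open, on these data alone, is whether a different group at this position, such as an amine, a hydroxy or a carboxylic acid, would move the number beyond the scatter.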